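Solubility notes: amide substituent exchange on the shared core

A few compounds are considered here, and "the series" means these few. Any claim that something is new, unique, unknown or untested is made for them only; others in the source may bear on it.

Measured compounds:
- compound 1, `COc1ccc2nc(C(F)(F)F)cc(OCC(=O)Nc3cc(C)cc(C)c3)c2c1`: 15000 nM
- compound 2, `COc1ccc2nc(C)cc(OCC(=O)NCc3cc(C)cc(C)c3)c2c1`: 92000 nM

In a physicochemical assay for solubility, in phosphate buffer, measured as kinetic solubility, with a stated time of 1 h, at pH 7.4 (a lower number here means a less soluble compound, a higher number a more soluble compound), compound 2 gives 92000 nM, the higher of the two numbers recorded so far; in this assay compound 1 gives 15000 nM, and the gap between the two lies beyond the scatter. Going by the values given here, no single-change step between measured compounds is available, so the two values stand on their own.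

Compound 3, `COc1ccc2nc(C)cc(OCC(=O)NC3CONC3=O)c2c1`, is not yet measured. It differs from compound 2 at one place: a group of 6 heavy atoms (3 carbon, 1 nitrogen, 2 oxygen; one five-membered non-aromatic ring with 2 hetero atoms) in place of a group of 9 heavy atoms (9 carbon; one six-membered aromatic ring of carbon only), on an amide-type nitrogen. The part that leaves carries no donors or acceptors; the part that enters brings one donor and two acceptors, as counted above.

The step from compound 2 to compound 3 is expected to be upward, beyond the scatter, as a 2.7-fold higher number from compound 2 to compound 3 (0.43 log units; beyond the scatter). Compound 3 is therefore estimated at 250000 nM, with a range from 90000 nM to 600000 nM; an upper limit of the assay may be reported instead of a number.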

Compound 3, solubility: >= 166000 nM
Compound 3 was reported as a limit; the forecaster's own chance of this, stated with the estimate: 30%; the middle value is on the limit's open side.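

Going by these compounds alone, on the amide-type nitrogen, exchanging 3,5-dimethylbenzyl for the five-membered non-aromatic ring with 2 hetero atoms gives the first single-change step, read in this assay as an at least 1.8-fold higher number from compound 2 to compound 3 (0.25 log units; that floor lies within the scatter). In this assay compound 3 gives >= 166000 nM, which is a limit of the assay and not a number. The step is therefore a floor only, and its true size stays unread because the reading stops at the limit: the limit of >= 166000 nM in this assay, at which 1 of the 3 values shown sits.

Within the data shown here, the single step removes the aromatic ring and brings in the new ring together, so the contribution of each part remains unseparated. Also open, on these data alone, is how a small acyclic group, such as a simple amine-bearing ethyl chain or a carboxylic acid on a short chain, would read on this same amide-type nitrogen.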